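The source may hold more compounds than are shown below. What is called first, only, known or untested is meant among the compounds shown, and "the series" means these compounds.

Measured in a functional assay on the whole organism (strain Wistar) for inhibition, with Rattus norvegicus as the target, read by paw edema, with stated times of 30 min and 3 h, at a dose of 100 mg/kg by the oral route; a lower number here means less inhibition, a higher number more inhibition at the dose given (going by the name of the read-out):
compound 1 `COc1cc(C(=O)N(C)C)nn1-c1ccccc1` gives 47.5%
compound 2 `CCCOc1cc(C(=O)N(C)C)nn1-c1ccccc1` gives 26.2%
compound 3 `CCCCOc1cc(C(=O)N(C)C)nn1-c1ccccc1` gives 18.7%

Compound 3 holds the lowest of these three numbers: it sits apart from compound 2 by a number 7.5 percentage points lower from compound 2 to compound 3 (within the scatter), within the scatter, and apart from compound 1 by a number 28.8 percentage points lower from compound 1 to compound 3 (beyond the scatter). Compound 4 `CCCCOc1cc(C(=O)NCCO)nn1-c1ccccc1` keeps the rest of compound 3 and differs only at the carbonyl carbon: (2-hydroxyethyl)amino in place of dimethylamino on a carbonyl carbon. Among the compounds with values here, no measured step touches that part of the molecule; the two steps beyond the scatter, a number 21.3 percentage points lower from compound 1 to compound 2 (beyond the scatter) and a number 28.8 percentage points lower from compound 1 to compound 3 (beyond the scatter), concern only the chain on the oxygen of the aromatic ring. There is thus no measured guide for direction, and the expected step is a number 0.7 percentage points lower from compound 3 to compound 4 (within the scatter), not beyond the scatter. Compound 4 is estimated at 18%, within 4% to 36%.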

Compound 4, a percentage reported as inhibition, in the whole organism at one dose (the size of the read-out at that dose, not a potency): 61.2%
For compound 4 the middle estimate is 43.2 percentage points below the measured one; measured number outside the range, above it.
By their numbers in this assay, from the lowest: compounds 3 and 2 (each within the scatter of the next); then compound 1; then compound 4.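

The group on the carbonyl carbon clearly matters in this assay: (2-hydroxyethyl)amino in place of dimethylamino gives a number 42.5 percentage points higher from compound 3 to compound 4 (beyond the scatter). Within the data shown here, the earlier steps changed only the chain on the oxygen of the aromatic ring, so this is the first view of how the other end of the molecule can shift the result. No evidence here bears on the reason for this step. Open, from the compounds shown here alone, is whether the hydroxyl or the amide hydrogen matters more, which ethylamino or methylamino could help separate. Also open, going by these compounds, is whether 3-hydroxypropylamino, with its longer chain, would do the same.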